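The source may hold more compounds than are shown below. What is called first, only, known or untested is meant among the compounds shown, and "the series" means these compounds.

The measured compounds and their values:

Compound 1, `O=S(=O)(c1ccccc1)c1nc2ccccc2nc1Nc1ccc(Cl)cc1`: 1920 nM
Compound 2, `O=S(=O)(c1ccccc1)c1nc2ccccc2nc1Nc1ccc(C(F)(F)F)cc1`: 300 nM
Compound 3, `O=S(=O)(c1ccc(Br)cc1)c1nc2ccccc2nc1Nc1ccc(Cl)cc1`: 16400 nM

The three compounds share one core and were tested in a functional assay on HL-60 cells (Homo sapiens) for cytotoxicity, read by MTT assay, with a stated time of 72 h; on this read-out lower numbers stand for stronger inhibition and higher numbers for weaker inhibition. Compound 1 gives 1920 nM in this assay. Compound 2 differs from compound 1 by trifluoromethyl in place of chloro on an aromatic carbon, and this change gives a 6.4-fold lower number from compound 1 to compound 2 (0.81 log units; beyond the scatter). Compound 3 differs from compound 1 by bromo in place of hydrogen on an aromatic carbon, and that change gives an 8.5-fold higher number from compound 1 to compound 3 (0.93 log units; beyond the scatter), leaving compound 3 with the highest number of the three.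

Compound 4, `O=S(=O)(c1ccc(Br)cc1)c1nc2ccccc2nc1Nc1ccc(C(F)(F)F)cc1`, has not yet been measured. It differs from compound 3 by trifluoromethyl in place of chloro on an aromatic carbon, the same change already seen between compound 1 and compound 2. Since the change lies at the same place in both pairs, a step close to the earlier one is expected: for compound 4 the estimate means a 5.5-fold lower number from compound 3 to compound 4 (0.74 log units; beyond the scatter), resting on compound 1 and compound 2, where the same change gave a 6.4-fold lower number from compound 1 to compound 2 (0.81 log units; beyond the scatter). Compound 4 is therefore expected to give about 3000 nM, most likely between 1000 nM and 10000 nM.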

Compound 4, half-maximal inhibitory concentration: 280 nM
Beside the measured number, compound 4's estimate is 11-fold (1.03 log units) above it; the measured number lies below the stated range.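

In this assay, trifluoromethyl in place of chloro gives a 59-fold lower number from compound 3 to compound 4 (1.77 log units; beyond the scatter), which has the same direction as the earlier pair but not the same size: the same change on two cores in this assay, a 6.4-fold lower number (0.81 log units; beyond the scatter) from compound 1 to compound 2 and a 59-fold lower number (1.77 log units; beyond the scatter) from compound 3 to compound 4, 9.2-fold (0.96 log units) apart, beyond the scatter of two such steps

Bromo in place of hydrogen gives a 1.1-fold lower number from compound 2 to compound 4 (0.03 log units; within the scatter), so the rise seen with chloro in the shared core does not appear with trifluoromethyl: the same change on two cores in this assay, an 8.5-fold higher number (0.93 log units; beyond the scatter) from compound 1 to compound 3 and a 1.1-fold lower number (0.03 log units; within the scatter) from compound 2 to compound 4, 9.2-fold (0.96 log units) apart, beyond the scatter of two such steps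

In these four compounds, then, the size of each step depends on the group at the other place, and a step measured on one core cannot be carried unchanged to the other, although the data do not show why this happens or whether it extends beyond these compounds.

Going by these compounds, it remains open whether a nitrile or a methoxy group in place of trifluoromethyl, or a fluoro or methyl group in place of bromo, would show the same dependence. On these data alone, it is also open whether the same dependence would appear with an amine on either aromatic ring.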